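A few compounds are considered here, and "the series" means these few. Any claim that something is new, unique, unknown or untested is made for them only; others in the source may bear on it.

Measured so far:
Compound 1 `Cc1ccc(CNC(=O)c2cccc(C(C)Oc3ccnc(Nc4cnn(C)c4)c3)c2)cc1` gives 7700 nM in a functional assay on NCI-H3122 cells (Homo sapiens) for antiproliferative activity, read by MTT assay, with a stated time of 48 h; a higher number here means a weaker inhibitor, a lower number a stronger inhibitor.
Compound 2 `Cc1ccc(CNC(=O)c2cccc(C(C)Oc3ccnc(NN4CCN(C)CC4)c3)c2)cc1` gives 8100 nM in this assay.

Compound 2 and compound 1 sit within the scatter of each other, so neither stands apart. Compound 3 `Cc1ccc(CNC(=O)c2cccc(C(C)Oc3ccnc(Nc4cnn(CC(C)(C)O)c4)c3)c2)cc1` differs from compound 2 by 1-(2-hydroxy-2-methylpropyl)-1H-pyrazol-4-yl in place of 4-methylpiperazin-1-yl on a nitrogen on an aromatic ring. For the measured compounds named here, the one measured step that bears on this, a 1.1-fold higher number from compound 1 to compound 2 (0.02 log units; within the scatter), exchanged the same two ring types in the other direction and stayed within the scatter. The step of a 1.2-fold lower number from compound 2 to compound 3 (0.06 log units; within the scatter) is therefore expected to be small, with no direction beyond the scatter. Compound 3 is estimated at 7000 nM, between 3000 nM and 18000 nM.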

Compound 3, half-maximal inhibitory concentration: > 100000 nM
Compound 3 was reported as a limit; the forecaster's own chance of this, stated with the estimate: 5%; at least 14-fold (1.15 log units) between middle value and limit.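

Compound 3 is reported only as a limit of the assay, not as a number: the limit of > 100000 nM in this assay, at which 1 of the 3 values shown sits. The earlier exchange of rings moved nothing, but this place is not indifferent: 1-hydroxy-1-methylethyl in place of hydrogen on a saturated chain carbon bound to an aromatic nitrogen gives an at least 12-fold higher number from compound 1 to compound 3 (1.11 log units; beyond the scatter). Against the piperazine, the substituted pyrazole gives an at least 12-fold higher number from compound 2 to compound 3 (1.09 log units; beyond the scatter), so the two rings are interchangeable only with the small methyl group on the pyrazole.

Whether the hydroxyl or the branched carbon chain accounts for this stays open; a plain isobutyl group or a chain ending in an amine at that place would separate the two.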